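Arylamino in place of the piperazine on the shared core

The source may report more compounds than this note shows. Statements on the series, on what has been measured and on what is new or still open speak of the compounds shown alone.

Going by the values given here, compound 1 `CN1CCN(c2nc(Cl)nc3c2ncn3Cc2ccc(C(=O)Nc3ccccc3N)cc2)CC1` holds the higher of the two values measured so far. In a functional assay on HepG2 cells (Homo sapiens) for antiproliferative activity, read by CCK-8 assay, with a stated time of 72 h, tested at 2 uM (a higher number here means a stronger effect of the compound at the concentration tested, a lower number a weaker effect), compound 1 gives 60.4%. Compound 2 `Cc1ccc(Nc2nc(Cl)nc3c2ncn3Cc2ccc(/C=C/C(=O)Nc3ccccc3N)cc2)cc1` is the only other measured entry; in this assay compound 2 gives 33.6%, a reading that lies beyond the usual scatter below that of compound 1. Among the compounds with values here, compound 2 differs from compound 1 in more than one place, so no single-change step exists within this set.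

Compound 3 `Nc1ccccc1NC(=O)c1ccc(Cn2cnc3c(Nc4cccc(Cl)c4)nc(Cl)nc32)cc1` has not yet been measured. It differs from compound 1 in one place: (3-chlorophenyl)amino in place of 4-methylpiperazin-1-yl on an aromatic carbon. Within the data shown here, with no clean step available, the expectation leans on compound 2, whose value 33.6% is the only reading for an arylamino group on the core. A step of a number 15.4 percentage points lower from compound 1 to compound 3 (beyond the scatter) is expected, downward but modest. Compound 3 is estimated at 45%, with a likely range from 25% to 65%.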

Compound 3, a percentage reported as inhibition, at one concentration (the size of the read-out at that concentration, not a potency): 29.9%
The estimate for compound 3 lay 15.1 percentage points above the measured number; the range from low to high includes it.
By their numbers in this assay, from the lowest: compounds 3 and 2 (each within the scatter of the next); then compound 1.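

In this assay, going by these compounds alone, placing (3-chlorophenyl)amino in place of 4-methylpiperazin-1-yl on this aromatic carbon gives a number 30.5 percentage points lower from compound 1 to compound 3 (beyond the scatter), the first single-change reading. With the rest of compound 1 held constant, the loss can be assigned to this one exchange, so the read-out at the tested concentration is sensitive to the group at this position. No measured information on the origin of the loss is available, and the step stands as an observation only.

The compounds shown do not reveal how morpholine or dimethylamino, as other non-aryl amines at this carbon, would compare with 4-methylpiperazin-1-yl. They also include no unsubstituted phenylamino group, so the contribution of the chlorine to the step cannot be separated from that of the aromatic ring.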